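The source may hold more compounds than are shown below. What is called first, only, known or untested is meant among the compounds shown, and "the series" means these compounds.

Compound 1 `C=C1C(=O)[C@@]23C(=O)OC[C@]4([C@@H](OC(C)=O)CCC(C)(C)[C@H]4C=O)[C@@H]2CC[C@H]1[C@H]3OC(=O)CC` is the reference point of this account. In a functional assay on Bel-7402 cells (Homo sapiens) for inhibition, read by MTT assay (a lower number here means a stronger inhibitor, a higher number a weaker inhibitor), compound 1 gives 3780 nM, the highest of the two numbers recorded. For the measured compounds named here, its only measured neighbour is compound 2 `C=C1C(=O)[C@@]23C(=O)OC[C@]4([C@@H](OC(C)=O)CCC(C)(C)[C@H]4C=O)[C@@H]2CC[C@H]1[C@H]3OC(=O)c1ccc([N+](=O)[O-])cc1`, which in this assay gives 1740 nM; the step of a 2.2-fold lower number from compound 1 to compound 2 (0.34 log units; beyond the scatter) is the one measured change on this carbonyl carbon. Compound 3 `C=C1C(=O)[C@@]23C(=O)OC[C@]4([C@@H](OC(C)=O)CCC(C)(C)[C@H]4C=O)[C@@H]2CC[C@H]1[C@H]3OC(=O)c1ccccc1Cl` is not yet measured. It differs from compound 1 by 2-chlorophenyl in place of ethyl on a carbonyl carbon. The step from compound 1 to compound 2 bears on it, since both changes replace the ethyl on that carbonyl carbon with an aromatic ring; that step was modest and beyond the scatter. Going by the values given here, a comparable modest drop is therefore expected, though the one aryl example is too few to fix its size. For compound 3 in this assay the expected value is 2200 nM, between 1000 nM and 5000 nM, an expected step of a 1.7-fold lower number from compound 1 to compound 3 (0.24 log units; within the scatter).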

Compound 3, half-maximal inhibitory concentration: 1390 nM
The estimate for compound 3 lay 1.6-fold (0.20 log units) above the measured number; low and high end bracket the measured number.
By their numbers in this assay, from the lowest: compounds 3 and 2 (each within the scatter of the next); then compound 1.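

In this assay a second aromatic group on this carbonyl carbon again goes with a lower number, a 2.7-fold lower number from compound 1 to compound 3 (0.43 log units; beyond the scatter), so the drop seen earlier is no longer tied to 4-nitrophenyl alone, and no compound shown goes against it. The two aromatic groups cannot be told apart here, with a 1.3-fold lower number from compound 2 to compound 3 (0.10 log units; within the scatter), so exchanging 4-nitrophenyl for 2-chlorophenyl leaves the result effectively unchanged. Nothing available explains either the drop from the ethyl compound or the likeness of the two aromatic compounds.

Whether the drop requires an aromatic ring remains open, since neither cyclohexyl nor a longer chain such as hexyl stands on this carbonyl carbon among the compounds shown. Also open, on these data alone, is how unsubstituted phenyl, or a phenyl carrying an amine or a carboxylic acid, would compare.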